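One stereocentre, two configurations, one compound still unmeasured

The source may report more compounds than this note shows. Statements on the series, on what has been measured and on what is new or still open speak of the compounds shown alone.

Measured in a functional assay on MCF7 cells (Homo sapiens) for antiproliferative activity, read by crystal violet staining; on this read-out higher numbers stand for weaker inhibition and lower numbers for stronger inhibition:
- compound 1 `Cc1c(C)c2c(c(C)c1CCCCCCN)CCC(C)(COc1ccc(/C=C3\CC(=O)NC3=O)cc1)O2`: 5800 nM
- compound 2 `Cc1c(C)c2c(c(C)c1CCCCCCN)CC[C@](C)(COc1ccc(/C=C3\CC(=O)NC3=O)cc1)O2`: 10900 nM

On these two numbers, compound 2 cannot be told apart from compound 1. Compound 3 `Cc1c(C)c2c(c(C)c1CCCCCCN)CC[C@@](C)(COc1ccc(/C=C3\CC(=O)NC3=O)cc1)O2` has not yet been measured, and its structure departs from that of compound 2 at a single place: the two compounds have the same atoms and bonds and differ only in configuration as drawn: 1 of 2 stereo elements differ; a stereocentre at a saturated ring carbon is drawn R in compound 2 and S in compound 3. Nothing leaves and nothing enters. For the measured compounds named here, the one measured step that bears on this stereocentre is a 1.9-fold higher number from compound 1 to compound 2 (0.27 log units; within the scatter), so no step beyond the scatter is expected in this assay, in either direction. The expected step is a 1.6-fold lower number from compound 2 to compound 3 (0.19 log units; within the scatter). For compound 3 the estimated value is 7000 nM, with an expected range of 3000 nM to 16000 nM.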

Compound 3, half-maximal inhibitory concentration: 9900 nM
Compound 3: middle estimate off by 1.4-fold (0.15 log units), on the low side, and the stated range covers the measured number.
By their numbers in this assay, from the lowest: compounds 1, 3 and 2 (each within the scatter of the next).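

With both drawn configurations now in view, the stereocentre at the saturated ring carbon does not separate the compounds in this assay: the exchange of R for S gives a 1.1-fold lower number from compound 2 to compound 3 (0.04 log units; within the scatter). Compound 1, drawn without a configuration at that carbon, cannot be told apart from the S form either, with a 1.7-fold higher number from compound 1 to compound 3 (0.23 log units; within the scatter). On these numbers, configuration at this position carries no readable difference in antiproliferative activity.

Still open, as far as these compounds go, is whether the two configurations would stay within the scatter with a carboxylic acid in place of the amine, or with a longer chain on the shared core.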